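From Piperidin-4-yl to a Larger Ring Group

The source may hold more compounds than are shown below. What is called first, only, known or untested is meant among the compounds shown, and "the series" means these compounds.

Measured in a functional assay on MKN-45 cells (Homo sapiens) for antiproliferative activity, read by CellTiter-Glo, with a stated time of 3 days; on this read-out lower numbers stand for stronger inhibition and higher numbers for weaker inhibition:
Compound 1 `C[C@@H](Oc1c(N)ncc2c(-c3ccncc3)coc12)c1c(Cl)ccc(F)c1Cl` gives 900 nM
Compound 2 `C[C@@H](Oc1c(N)ncc2c(C3CCNCC3)coc12)c1c(Cl)ccc(F)c1Cl` gives 3100 nM

Of these two compounds, compound 2 has the higher number and so the weaker inhibition. Among the compounds with values here, the only measured step is a 3.4-fold higher number from compound 1 to compound 2 (0.54 log units; beyond the scatter), with piperidin-4-yl taking the place of pyridin-4-yl on an aromatic carbon. Compound 3 `CC(=O)N1CC=C(c2coc3c(O[C@H](C)c4c(Cl)ccc(F)c4Cl)c(N)ncc23)CC1` has not yet been measured. It carries a group of 9 heavy atoms (7 carbon, 1 nitrogen, 1 oxygen; one six-membered non-aromatic ring with 1 hetero atom) in place of a group of 6 heavy atoms (5 carbon, 1 nitrogen; one six-membered non-aromatic ring with 1 hetero atom), on an aromatic carbon, at the same aromatic carbon, two ring bonds from the ring oxygen. Within the data shown here, that single step changed the group at this carbon and is the only guide, and it shows that this place responds modestly. The new group is neither of the two measured ones, so the expectation rests on compound 1 at 900 nM and compound 2 at 3100 nM, and a result between them seems likely. The expected change is a modest one toward stronger inhibition, estimated as a 2.2-fold lower number from compound 2 to compound 3 (0.35 log units; beyond the scatter). For compound 3 the estimate is 1400 nM, with an expected range of 450 nM to 4000 nM.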

Compound 3, half-maximal inhibitory concentration: 330 nM
Estimate against measurement, compound 3: 4.2-fold (0.63 log units) above, and the stated range ends above it.
By their numbers in this assay, from the lowest: compound 3; then compound 1; then compound 2.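

In this assay the new group gives a 9.4-fold lower number from compound 2 to compound 3 (0.97 log units; beyond the scatter) and a 2.7-fold lower number from compound 1 to compound 3 (0.44 log units; beyond the scatter), so at this position the outcome does not have to fall between those of piperidin-4-yl and pyridin-4-yl. The earlier step alone could have suggested that a non-aromatic six-membered ring is a drawback here, but the entering group also has such a ring and gives the lowest number of the three compounds. Nothing available explains this gain.

Going by these compounds, the entering group differs from piperidin-4-yl in both the acetyl group on the ring nitrogen and the double bond in the ring, so the contribution of each remains open. A saturated piperidine ring carrying the same acetyl group would separate the two, while a methanesulfonyl group on the ring nitrogen would test whether an acetyl group is specifically needed.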